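The source may report more compounds than this note shows. Statements on the series, on what has been measured and on what is new or still open speak of the compounds shown alone.

Of the compounds shown here, three built on one shared core have so far been measured in an assay on isolated protein for inhibition of alkaline phosphatase, tissue-nonspecific isozyme (Homo sapiens); on this read-out higher numbers stand for weaker inhibition and lower numbers for stronger inhibition. Compound 1 `CC(C)NC(=O)c1cc(-c2ccc(Cl)cc2Cl)n[nH]1` gives 51 nM. Compound 2 `CN(C)C(=O)c1cc(-c2cc(F)c(Cl)cc2Cl)n[nH]1` gives 324 nM. Compound 3 `O=C(c1cc(-c2ccc(Cl)cc2Cl)n[nH]1)N(CCO)CCO` gives 47 nM, the lowest of the three numbers. Its nearest neighbour is compound 1: the step of a 1.1-fold lower number from compound 1 to compound 3 (0.04 log units; within the scatter) lies within the usual scatter, so these two cannot be told apart on this read-out. Compound 2, by contrast, gives a clearly higher number than compound 3, and this gap is beyond the scatter.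

Compound 4 `O=C(c1cc(-c2cc(F)c(Cl)cc2Cl)n[nH]1)N(CCO)CCO` is the next compound to be measured in this assay. It differs from compound 3 in a single place: fluoro in place of hydrogen on an aromatic carbon. Going by the values given here, no measured step isolates this change on its own. Among the compounds with values here, the only measured comparison that involves the fluoro is compound 2 against compound 1, and those two also differ at the amide, so when compound 2 gives 324 nM where compound 1 gives 51 nM, the higher number of compound 2 cannot be laid on the fluoro alone. A moderate rise is nonetheless the more likely outcome, so compound 4 is expected to give 110 nM, within a range from 40 nM to 320 nM. The expected step of a 2.3-fold higher number from compound 3 to compound 4 (0.37 log units; beyond the scatter) is therefore estimated to be small and upward.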

Compound 4, half-maximal inhibitory concentration: 127 nM
Compound 4: the middle estimate sits 1.2-fold (0.06 log units) below what was measured; low and high end bracket the measured number.
By their numbers in this assay, from the lowest: compounds 3 and 1 (each within the scatter of the next); then compound 4; then compound 2.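

Going by these compounds alone, compound 3 and compound 4 give the first clean reading of the fluoro on this aromatic carbon, ortho to a chloro group and para to a chloro group, in this assay: the single added atom gives a 2.7-fold higher number from compound 3 to compound 4 (0.43 log units; beyond the scatter). This is a modest but real loss of inhibition, so this position is not indifferent to a small change, at least with the bis(2-hydroxyethyl)amino amide in place. With the fluoro held fixed, the amide also matters, as bis(2-hydroxyethyl)amino in place of dimethylamino gives a 2.6-fold lower number from compound 2 to compound 4 (0.41 log units; beyond the scatter), which shows that the high number of compound 2 cannot be laid on the fluoro alone, and nothing available here says why either step occurs.

Within the data shown here, it remains open whether the fluoro would bring a similar rise on the isopropylamino amide of compound 1, since the step has been read on only one pair. Also open, going by these compounds, is how a methyl group, a methoxy group or a nitrile on this same aromatic carbon would compare with hydrogen and fluoro.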